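The source may report more compounds than this note shows. Statements on the series, on what has been measured and on what is new or still open speak of the compounds shown alone.

Compound 1, `O=C(CCC1=CCN(CCCc2ccc(Br)cc2)C1=O)NO`, is one of three compounds already measured in a functional assay on NUGC-3 cells (Homo sapiens) for inhibition, read by sulforhodamine B assay (a higher number here means a weaker inhibitor of growth, a lower number a stronger inhibitor of growth), where compound 1 gives 2200 nM. Its partner compound 2, `O=C(CCC1=CCN(CCCc2ccc(Cl)cc2)C1=O)NO`, gives in this assay 2200 nM. The two differ by chloro in place of bromo on an aromatic carbon, and the step of no change at the digits printed from compound 1 to compound 2 (within the scatter). Compound 3, `O=C(CCC1=CCN(Cc2cccc(Br)c2)C1=O)NO`, gives in this assay 4280 nM; the difference between the core of compound 3 and the core of compound 1 is not broken down here, and the values of compound 3 and compound 1 are within the scatter of each other.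

Compound 4, `O=C(CCC1=CCN(Cc2cccc(Cl)c2)C1=O)NO`, has not yet been measured. It differs from compound 3 by chloro in place of bromo on an aromatic carbon. This is the same kind of change as that from compound 1 to compound 2, though there the chloro sits para to a large group and here it sits meta to a large group.

Because the step of no change at the digits printed from compound 1 to compound 2 (within the scatter) was flat, the step from compound 3 to compound 4 is expected to be a 1.0-fold higher number from compound 3 to compound 4 (0.00 log units; within the scatter). Compound 4 is therefore estimated in this assay at 4300 nM, between 2100 nM and 8800 nM.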

Compound 4, concentration for 50% growth inhibition: 4280 nM
Beside the measured number, compound 4's estimate is 1.0-fold (0.00 log units) above it; low and high end bracket the measured number.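

In this assay, putting chloro in place of bromo on the aromatic carbon gives no change at the digits printed from compound 3 to compound 4 (within the scatter), and this agrees with what the same change did on the other core: the same change on two cores in this assay, no change at the digits printed (within the scatter) from compound 1 to compound 2 and no change at the digits printed (within the scatter) from compound 3 to compound 4, 1.0-fold (0.00 log units) apart, within the scatter of two such steps Within this series, then, the exchange of these two halogens carries from one core to the other without a visible difference in growth inhibition. Among these compounds, this rests on only two pairs and one exchange in a single assay, so it does not show that the flat result would hold on any other core or in any other measurement, and it gives no reason for it.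

The compounds shown leave open whether a fluoro, a methoxy, an amine or a carboxylic acid on the same aromatic ring would also leave the value in place. They also leave open what a longer chain alone would do, since compound 1 and compound 3 differ in more than one place and their cores cannot be separated into single changes.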